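A few compounds are considered here, and "the series" means these few. Any claim that something is new, unique, unknown or untested is made for them only; others in the source may bear on it.

Compound 1 `Brc1ccc2ncnc(Nc3ccccc3)c2c1` carries a phenylamino group on a bromo-substituted core. In a functional assay on HEK293 cells for antagonist activity at metabotropic glutamate receptor 5 (Rattus norvegicus), read by calcium flux (on this read-out higher numbers stand for weaker inhibition and lower numbers for stronger inhibition), compound 1 gives > 10000 nM, which is a limit of the assay rather than a number; it is the limit of > 10000 nM in this assay, at which 1 of the 3 values shown sits.

Compound 2 `Fc1cccc(Nc2ncnc3ccc(Br)cc23)c1` differs from compound 1 by fluoro in place of hydrogen on an aromatic carbon. In this assay compound 2 gives 1970 nM, so the change brings an at least 5.0-fold lower number from compound 1 to compound 2 (0.70 log units; beyond the scatter).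

Compound 3 `Fc1ccc2ncnc(Nc3cccc(Cl)c3)c2c1` has a different core from compound 1 and a chloro group on the outer ring; the difference between the two cores is not broken down here. In this assay compound 3 gives 311 nM, the lowest of the two plain numbers, with compound 2 next at a higher value.

Compound 4 `Fc1ccc2ncnc(Nc3cccc(Cl)c3F)c2c1` is not yet measured. It differs from compound 3 by fluoro in place of hydrogen on an aromatic carbon. Within the data shown here, this is the same kind of change as the one from compound 1 to compound 2, but not the same: in compound 2 the fluoro sits meta to a large group, while in compound 4 it sits ortho to a chloro group and ortho to a large group.

For compound 4 the expected step is a 2.1-fold lower number from compound 3 to compound 4 (0.32 log units; beyond the scatter), resting on the earlier fluoro step an at least 5.0-fold lower number from compound 1 to compound 2 (0.70 log units; beyond the scatter) while allowing for the different surroundings. The estimate for compound 4 in this assay is 150 nM, expected to fall between 50 nM and 600 nM.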

Compound 4, half-maximal inhibitory concentration: 3720 nM
For compound 4 the middle estimate is 25-fold (1.39 log units) below the measured one; the whole stated range lies below it.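

In this assay, putting fluoro in place of hydrogen on the outer ring of compound 3 gives a 12-fold higher number from compound 3 to compound 4 (1.08 log units; beyond the scatter), so a change that went with a lower number on the core of compound 1 goes with a higher number here. The same swap therefore does not carry over from one core to the other in this series, and the two results differ in direction as well as size: the same change on two cores in this assay, an at least 5.0-fold lower number (0.70 log units; beyond the scatter) from compound 1 to compound 2 and a 12-fold higher number (1.08 log units; beyond the scatter) from compound 3 to compound 4, at least 60-fold (1.78 log units) apart, beyond the scatter of two such steps This does not show what reverses the effect, since the two pairs differ in more than the core: in compound 4 the fluoro sits ortho to a chloro group and ortho to a large group, and compound 2 has no chloro group, so the core and the chloro group cannot be told apart, while the earlier step starts from a limit of the assay and gives only a bound on its size.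

As far as these compounds go, it stays open whether the fluoro would raise the number on the core of compound 3 with no chloro group present on the outer ring. From the compounds shown here alone, it is also open whether a methyl group or a methoxy group in the fluoro's place would give a number nearer that of compound 3 or that of compound 4.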